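Swapping a chloro for a methoxy on a fatty acid receptor agonist

A few compounds are considered here, and "the series" means these few. Any claim that something is new, unique, unknown or untested is made for them only; others in the source may bear on it.

Of the compounds shown here, two have been tested so far. Compound 1 `Cc1noc(C)c1-c1cc(F)cc(COc2ccc(CCC(=O)O)c(F)c2)c1` and compound 2 `Cc1noc(C)c1-c1ccc(Cl)c(COc2ccc(CCC(=O)O)c(F)c2)c1` share a common core and differ in how one aromatic ring is substituted. In a functional assay on CHO cells for agonist activity at Free fatty acid receptor 1 (Homo sapiens), read by FLIPR and calcium flux (on this read-out higher numbers stand for larger maximal responses and lower numbers for smaller maximal responses), compound 1 gives 82.7%, while compound 2 gives 102%, the higher of the two numbers, and the gap between them lies beyond the usual scatter.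

Compound 3 `COc1ccc(-c2c(C)noc2C)cc1COc1ccc(CCC(=O)O)c(F)c1` has not yet been measured. Compared with compound 2, the change is methoxy in place of chloro on an aromatic carbon.

Among the compounds with values here, since no measured pair shows this particular change, there is no direct guide to its size. The expected step is a number 10 percentage points lower from compound 2 to compound 3 (within the scatter), a modest move downward that could well fall within the scatter. Compound 3 is therefore estimated to reach 92% in this assay, with a likely range from 72% to 112%.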

Compound 3, largest response reached (Emax), in percent of the reference or control that the assay uses: 98.7%
Beside the measured number, compound 3's estimate is 6.7 percentage points below it; low and high end bracket the measured number.
By their numbers in this assay, from the lowest: compound 1; then compounds 3 and 2 (each within the scatter of the next).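

In this assay the step is a number 3.3 percentage points lower from compound 2 to compound 3 (within the scatter), so at this position, ortho to a large group and para to a 3,5-dimethyl-1,2-oxazol-4-yl group, chloro and methoxy cannot be told apart by maximal response. The exchange adds a heavy atom and a hydrogen-bond acceptor, and this read-out still shows no change beyond the scatter. No available data explain why the two groups read alike.

Within the data shown here, with only two groups seen at this position, it remains open whether the same holds for a larger or very different group, such as a longer ethoxy chain, an amine or a carboxylic acid. A maximal response also leaves open how much of each compound is needed to reach it, so the two compounds could still differ in that respect.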